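A few compounds are considered here, and "the series" means these few. Any claim that something is new, unique, unknown or untested is made for them only; others in the source may bear on it.

Three compounds share one core and a benzyl ester, and differ only in the group on the saturated chain carbon bound to an amide-type nitrogen and a carbonyl carbon. In a functional assay on HL-60 cells (Homo sapiens) for antiproliferative activity, read by MTT assay, with a stated time of 48 h (on this read-out lower numbers stand for stronger inhibition and higher numbers for weaker inhibition), compound 1 `CC(C)[C@H](NC(=O)c1cc2ccccc2cn1)C(=O)OCc1ccccc1` gives 78.9 nM. Compound 2 `O=C(N[C@@H](CO)C(=O)OCc1ccccc1)c1cc2ccccc2cn1` gives 70.4 nM in this assay, and compound 3 `O=C(C[C@H](NC(=O)c1cc2ccccc2cn1)C(=O)OCc1ccccc1)OCc1ccccc1` gives 74 nM. Compound 3 sits among its two neighbours: the change is a 1.1-fold lower number from compound 1 to compound 3 (0.03 log units; within the scatter), and it is a 1.1-fold higher number from compound 2 to compound 3 (0.02 log units; within the scatter); the remaining pair shows a 1.1-fold lower number from compound 1 to compound 2 (0.05 log units; within the scatter). Every swap of that side group so far has left the number essentially where it was.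

Compound 4 `O=C(CC[C@H](NC(=O)c1cc2ccccc2cn1)C(=O)OCc1ccccc1)OCc1ccccc1` carries a longer version of the side chain of compound 3: (benzyloxycarbonyl)methyl in place of benzyloxycarbonyl on a saturated chain carbon, two bonds along the chain from an amide-type nitrogen and a carbonyl carbon. All three measured steps bear on this change, since each also exchanged the group on that chain carbon, and none moved the number beyond the scatter. A longer chain ending in the same ester is therefore expected to behave alike, so the step from compound 3 to compound 4 is expected to be a 1.0-fold higher number from compound 3 to compound 4 (0.01 log units; within the scatter), with no direction that can be trusted. Compound 4 is estimated at 75 nM in this assay, within a range from 40 nM to 150 nM.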

Compound 4, half-maximal inhibitory concentration: 83.6 nM
The estimate for compound 4 lay 1.1-fold (0.05 log units) below the measured number; the range from low to high includes it.
By their numbers in this assay, from the lowest: compounds 2, 3, 1 and 4 (each within the scatter of the next).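

Going from (benzyloxycarbonyl)methyl to 2-(benzyloxycarbonyl)ethyl, one carbon longer, gives a 1.1-fold higher number from compound 3 to compound 4 (0.05 log units; within the scatter) in this assay, so lengthening the chain that carries the ester also leaves the number within the scatter. The wider swaps to this longer group read the same way, with a 1.2-fold higher number from compound 2 to compound 4 (0.07 log units; within the scatter) against hydroxymethyl and a 1.1-fold higher number from compound 1 to compound 4 (0.03 log units; within the scatter) against isopropyl , which means that all four side groups on the saturated chain carbon bound to an amide-type nitrogen and a carbonyl carbon give numbers that cannot be told apart in this assay, even though they range from a small hydroxy-bearing group to a long chain ending in a benzyl ester. Nothing available explains why this position tolerates such different groups.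

Going by these compounds, all four compounds keep the same core and the same benzyl ester, so the part played by that ester remains open, for instance whether a free carboxylic acid in its place would keep the number. On these data alone, on the side chain itself, it also remains open whether an amine or a free carboxylic acid at the chain end, or a still longer chain, would finally move the number beyond the scatter.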